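A few compounds are considered here, and "the series" means these few. Any claim that something is new, unique, unknown or untested is made for them only; others in the source may bear on it.

Measured so far in an assay (strain Wistar) for displacement of a labelled ligand from adenosine receptor A1 (Rattus norvegicus), read by scintillation counting; a lower number here means a stronger inhibitor, a higher number a weaker inhibitor:
- compound 1 `CCOc1ccccc1C(=O)Nc1nc(-c2ccccc2)nc2c1nnn2Cc1ccccc1`: 1850 nM
- compound 2 `O=C(Nc1nc(-c2ccccc2)nc2c1nnn2Cc1ccccc1)C1CCCCC1`: 12 nM
- compound 3 `COc1ccc(Cl)cc1C(=O)Nc1nc(-c2ccccc2)nc2c1nnn2Cc1ccccc1`: 7150 nM

Compound 3 gives the highest number of the three; its nearest neighbour is compound 1, reached by a 3.9-fold higher number from compound 1 to compound 3 (0.59 log units; beyond the scatter), and the widest gap is a 600-fold higher number from compound 2 to compound 3 (2.78 log units; beyond the scatter). Compound 4 `Nc1ccc(C(=O)Nc2nc(-c3ccccc3)nc3c2nnn3Cc2ccccc2)cc1` differs from compound 3 by 4-aminophenyl in place of 5-chloro-2-methoxyphenyl on a carbonyl carbon; the amide, the shared core and its substituents are unchanged. Both aryl amides sit far from the cyclohexyl amide, and the aryl-to-aryl change a 3.9-fold higher number from compound 1 to compound 3 (0.59 log units; beyond the scatter) was modest. Among the compounds with values here, the new aryl group carries neither an alkoxy nor a chloro substituent, so none of the measured steps covers it directly; a modest lowering in this assay is expected rather than a large one. Compound 4 is estimated at 600 nM (range 60 nM to 6000 nM), expected step a 12-fold lower number from compound 3 to compound 4 (1.08 log units; beyond the scatter).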

Compound 4, inhibition constant: 7.1 nM
Estimate against measurement, compound 4: 85-fold (1.93 log units) above; measured number outside the range, below it.
By their numbers in this assay, from the lowest: compounds 4 and 2 (each within the scatter of the next); then compound 1; then compound 3.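

In this assay an aryl group on the carbonyl carbon is compatible with a low number: 4-aminophenyl gives a 1000-fold lower number from compound 3 to compound 4 (3.00 log units; beyond the scatter) and a 260-fold lower number from compound 1 to compound 4 (2.42 log units; beyond the scatter) in this series. With a 1.7-fold lower number from compound 2 to compound 4 (0.23 log units; within the scatter) as the step, cyclohexyl and 4-aminophenyl are not told apart here. The high numbers therefore belong to 2-ethoxyphenyl and 5-chloro-2-methoxyphenyl, not to aryl amides as such.

The compounds shown do not separate the entering amine from the loss of the alkoxy and chloro substituents, a question an unsubstituted phenyl group would bear on. No evidence at hand speaks to the cause of these steps.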